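A few compounds are considered here, and "the series" means these few. Any claim that something is new, unique, unknown or untested is made for them only; others in the source may bear on it.

Three compounds of the series have numbers in a functional assay on RXF 393 cells (Homo sapiens) for cytotoxicity, read by sulforhodamine B assay, with a stated time of 48 h, tested at 0.1 uM; a lower number here means a stronger effect, a higher number a weaker effect of the compound at the concentration tested. Compound 1 `COc1cc(-c2cc(/C=C/C(=O)c3ccc(Cl)c(Cl)c3)[nH]n2)cc(OC)c1OC` gives 96%; compound 2 `COc1ccc(-c2cc(/C=C/C(=O)c3cc(OC)c(OC)c(OC)c3)[nH]n2)cc1OC` gives 102%; compound 3 `COc1ccc(C(=O)/C=C/c2cc(-c3cc(OC)c(OC)c(OC)c3)n[nH]2)cc1OC` gives 100%. Compound 3 stands second highest of the three, within the scatter of both compound 2 and compound 1, so no order among them can be read. Within the data shown here, the only step measured in one place, a number 4 percentage points higher from compound 1 to compound 3 (within the scatter), lies within the scatter. Compound 4 `COc1cc(C(=O)/C=C/c2cc(-c3cc(OC)c(OC)c(OC)c3)n[nH]2)cc(OC)c1OC` differs from compound 3 by methoxy in place of hydrogen on an aromatic carbon. Among the measured compounds shown here, no measured step involves this change, and the one step recorded, a number 4 percentage points higher from compound 1 to compound 3 (within the scatter), moved nothing beyond the scatter; all three numbers sit close together. The step of no change at the digits printed from compound 3 to compound 4 (within the scatter) is therefore expected to stay within the scatter. The estimate for compound 4 is 100%, with a range from 92% to 108%.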

Compound 4, a percentage reported as activity, at one concentration (the size of the read-out at that concentration, not a potency): 88%
For compound 4 the middle estimate is 12 percentage points above the measured one; the measured number lies below the stated range.
By their numbers in this assay, from the lowest: compounds 4, 1, 3 and 2 (each within the scatter of the next, the first and the last beyond it).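

In this assay, among these compounds, methoxy in place of hydrogen on an aromatic carbon, ortho to a methoxy group, gives a number 12 percentage points lower from compound 3 to compound 4 (beyond the scatter) and is the first change to move the number beyond the scatter. The same change on the other six-membered aromatic ring gives a number 14 percentage points lower from compound 2 to compound 4 (beyond the scatter) and so the effect is not confined to one ring, though both steps end at compound 4. Nothing measured here accounts for these steps.

On these data alone, whether ethoxy or an amine at this position would give a step of similar size remains open. Also open, as far as these compounds go, is whether hydroxy would do so on either ring.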